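Bromo for tert-Butyl on the Benzylamine Ring

A few compounds are considered here, and "the series" means these few. Any claim that something is new, unique, unknown or untested is made for them only; others in the source may bear on it.

Compound 1 `CC(C)(C)c1ccc(CNCCCNS(=O)(=O)c2cc(C(F)(F)F)cc(C(F)(F)F)c2)cc1` gives the lowest number of the three measured compounds in a functional assay on Capan-2 cells (Homo sapiens) for inhibition, read by MTT assay, with a stated time of 72 h (on this read-out higher numbers stand for weaker inhibition of growth and lower numbers for stronger inhibition of growth), at 2100 nM. Compound 3 `COc1ccccc1CNCCCNS(=O)(=O)c1cc(C(F)(F)F)cc(C(F)(F)F)c1` gives 6000 nM, and compound 2 `CN(CCCNS(=O)(=O)c1cc(C(F)(F)F)cc(C(F)(F)F)c1)Cc1ccccc1` gives 46000 nM. The measured steps are a 2.9-fold higher number from compound 1 to compound 3 (0.46 log units; beyond the scatter) and a 7.7-fold lower number from compound 2 to compound 3 (0.88 log units; beyond the scatter). Compound 4 `O=S(=O)(NCCCNCc1ccc(Br)cc1)c1cc(C(F)(F)F)cc(C(F)(F)F)c1` differs from compound 1 by bromo in place of tert-butyl on an aromatic carbon. Going by the values given here, no measured step exchanges one group for another at this aromatic carbon; the only change touching that ring, the step to compound 3, raised the number modestly, and the step to compound 2 concerns the amine nitrogen instead. Compound 4 is therefore expected to show a somewhat higher number, a step of about a 1.9-fold higher number from compound 1 to compound 4 (0.28 log units; within the scatter), estimated at 4000 nM within a range of 1500 nM to 12000 nM.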

Compound 4, concentration for 50% growth inhibition: 2000 nM
Beside the measured number, compound 4's estimate is 2.0-fold (0.30 log units) above it; the range from low to high includes it.
By their numbers in this assay, from the lowest: compounds 4 and 1 (each within the scatter of the next); then compound 3; then compound 2.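

In this assay, going by these compounds alone, this is the first direct exchange at this aromatic carbon, and a 1.1-fold lower number from compound 1 to compound 4 (0.02 log units; within the scatter) shows that bromo, with one heavy atom, reads the same as tert-butyl, with four. Compound 4 also keeps the distance from the other two compounds, with a 3.0-fold lower number from compound 3 to compound 4 (0.48 log units; beyond the scatter) and a 23-fold lower number from compound 2 to compound 4 (1.36 log units; beyond the scatter) in the same read-out. Nothing measured here explains why these two groups read alike.

On these data alone, whether a chloro or a methoxy group at this aromatic carbon would also read alike remains open. So does the effect of a methyl group on the amine nitrogen of compound 4.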